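Swapping the Nitrile for Methoxy on the Pyrazole

This account rests on a few compounds, and the source may have more. Where it says the series, first, only, none or still open, it means among the compounds named here.

Of the compounds shown here, three have been measured in a functional assay on cells for antagonist activity at Glucagon receptor (Homo sapiens), read by cAMP accumulation, in the presence of a further agent that is not named here; on this read-out lower numbers stand for stronger inhibition and higher numbers for weaker inhibition. Compound 1 `CCCC(Oc1ccc(-n2cc(C#N)cn2)cc1)c1ccc(C(=O)NCCC(=O)O)cc1` gives only a limit, > 50000 nM, so the assay reports no number for it. Compound 1 thus stands at the limit of > 50000 nM in this assay, at which 1 of the 3 values shown sits. Compound 2 `CCCC(Oc1ccc(-n2cc(C(F)(F)F)cn2)nc1)c1ccc(C(=O)NCCC(=O)O)cc1` gives 3700 nM in this assay, and compound 3 `CC(C)CC(Oc1ccc(-n2cc(C(F)(F)F)cn2)cc1)c1ccc(C(=O)NCCC(=O)O)cc1` gives 3400 nM; both carry a trifluoromethyl group and differ from compound 1 in more than one place, so no single step can be read from them. Compound 4 `CCCC(Oc1ccc(-n2cc(OC)cn2)cc1)c1ccc(C(=O)NCCC(=O)O)cc1` has not yet been measured. It differs from compound 1 by methoxy in place of cyano on an aromatic carbon. Among the measured compounds shown here, no measured step of this kind exists, and a modest improvement is expected, an at least 2.5-fold lower number from compound 1 to compound 4 (0.39 log units; beyond the scatter). Compound 4 is expected to give 20000 nM, within a range from 5000 nM to 60000 nM.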

Compound 4, antagonist equilibrium constant: > 23000 nM
Compound 4: only a limit was reported; the forecaster's own chance of this, stated with the estimate: 40%; at least 1.1-fold (0.06 log units) between middle value and limit.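

Compound 1 and compound 4 each give only a limit of the assay, and the step between them cannot be read. Going by these compounds, whether methoxy in place of cyano changes the inhibition at all, in either direction, stays open.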